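The source may report more compounds than this note shows. Statements on the series, on what has been measured and on what is new or still open speak of the compounds shown alone.

Of the compounds shown here, three sharing one core have been measured in a functional assay, tested at 200 ug/mL; on this read-out higher numbers stand for a stronger effect at the one concentration tested and lower numbers for a weaker effect. Compound 1 `N#CC1=C(N)OC(c2c[nH]c3ccccc23)=C(C#N)C1c1cccc2ccccc12` gives 7.7% in this assay. Compound 2 `N#CC1=C(N)OC(c2c[nH]c3ccccc23)=C(C#N)C1c1ccc(F)cc1` gives 22.4% in this assay, and compound 3 `CN(C)c1ccc(C2C(C#N)=C(N)OC(c3c[nH]c4ccccc34)=C2C#N)cc1` gives 20.5% in this assay. Compound 3 stands second highest of the three numbers, though its gap to compound 2, a number 1.9 percentage points lower from compound 2 to compound 3 (within the scatter), lies within the scatter, while its gap to compound 1, a number 12.8 percentage points higher from compound 1 to compound 3 (beyond the scatter), lies beyond it. The unmeasured compound 4 `COc1ccc(C2C(C#N)=C(N)OC(c3c[nH]c4ccccc34)=C2C#N)cc1OC` differs from compound 3 in one place: 3,4-dimethoxyphenyl in place of 4-(dimethylamino)phenyl on a saturated ring carbon. Two kinds of measured step bear on this. Replacing naphthalen-1-yl on the saturated ring carbon moved the number beyond the scatter, as in a number 14.7 percentage points higher from compound 1 to compound 2 (beyond the scatter) and a number 12.8 percentage points higher from compound 1 to compound 3 (beyond the scatter). Exchanging one substituent on the aromatic ring for another did not, as in a number 1.9 percentage points lower from compound 2 to compound 3 (within the scatter). Because a number 1.9 percentage points lower from compound 2 to compound 3 (within the scatter) stayed within the scatter, compound 4 is expected to shift by a number 0.5 percentage points lower from compound 3 to compound 4 (within the scatter) in this assay. Compound 4 is therefore estimated at 20%, with a range from 8% to 34%.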

Compound 4, a percentage reported as activity, at one concentration (the size of the read-out at that concentration, not a potency): 26.1%
Compound 4: the middle estimate sits 6.1 percentage points below what was measured, within the range that was stated.
By their numbers in this assay, from the lowest: compound 1; then compounds 3, 2 and 4 (each within the scatter of the next).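

On the saturated ring carbon, 3,4-dimethoxyphenyl carries two substituents on its phenyl ring, yet in this assay it stays level with the singly substituted phenyl groups (a number 5.6 percentage points higher from compound 3 to compound 4 (within the scatter); a number 3.7 percentage points higher from compound 2 to compound 4 (within the scatter)). Against naphthalen-1-yl the separation holds (a number 18.4 percentage points higher from compound 1 to compound 4 (beyond the scatter)), so all three substituted phenyl groups now stand apart from compound 1, while none stands apart from another. Nothing available explains why these groups read alike or why naphthalen-1-yl differs.

All the compounds shown carry an aromatic group at this carbon, so it remains open how a plain alkyl chain, or a phenyl ring bearing a carboxylic acid, would read here. The 1H-indol-3-yl and amino groups are also the same throughout, leaving their contribution untested.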